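A Methoxy Step Repeated on a Second Core

The compounds below may be only part of what the source reports. "The series", "measured", "known", "first", "only" and "open" are said of these compounds alone.

Compound 1 `Cc1noc(-c2cc3ccccc3[nH]2)n1` is tested in a functional assay on MCF7 cells (Homo sapiens) for antiproliferative activity, read by WST assay, with a stated time of 72 h (a lower number here means a stronger inhibitor, a higher number a weaker inhibitor), where compound 1 gives only a limit of the assay, > 50000 nM. Compound 2 `COc1ccc2[nH]c(-c3nc(C)no3)cc2c1` carries methoxy in place of hydrogen on an aromatic carbon and in this assay compound 2 gives 16700 nM. That change made an at least 2.9-fold lower number from compound 1 to compound 2 (0.47 log units; beyond the scatter).

Compound 3 `COc1ccc(-c2noc(-c3cc4ccccc4[nH]3)n2)cc1` shares the change in place with compound 1, but how the two cores differ is not broken down here. In this assay compound 3 gives only a limit, > 50000 nM. The picture so far is dominated by the limit of > 50000 nM in this assay, at which 2 of the 3 values shown sit.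

Compound 4 `COc1ccc(-c2noc(-c3cc4cc(OC)ccc4[nH]3)n2)cc1` differs from compound 3 by methoxy in place of hydrogen on an aromatic carbon, the same change as that from compound 1 to compound 2. Because that earlier step was an at least 2.9-fold lower number from compound 1 to compound 2 (0.47 log units; beyond the scatter), a step of similar size is expected here, so the estimated step is an at least 1.6-fold lower number from compound 3 to compound 4 (0.22 log units; that floor lies within the scatter). In this assay compound 4 is therefore expected to give about 30000 nM, within an estimated span from 8000 nM to 100000 nM, with a real chance that only a limit is reported again.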

Compound 4, half-maximal inhibitory concentration: > 50000 nM
Compound 4: no number, only a limit; the forecaster's own chance of this, stated with the estimate: 50%; at least 1.6-fold (0.22 log units) between middle value and limit.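

In this assay compound 4 gives only a limit, > 50000 nM. Within the data shown here, both ends of the methoxy step on this second core are limits, so the step from compound 3 to compound 4 cannot be read, and the result neither confirms nor refutes that the change carries over from the core of compound 1: the limit of > 50000 nM in this assay, at which 3 of the 4 values shown sit. The one new step that can be read, an at least 2.9-fold higher number from compound 2 to compound 4 (0.47 log units; beyond the scatter), is a different change, 4-methoxyphenyl in place of methyl with the methoxy kept, so it shows that this swap weakens the result on the methoxy-bearing core but says nothing about carrying the methoxy across.

As far as these compounds go, whether methoxy lowers the number at all on the core of compound 3 stays open, as does whether the gain seen on the core of compound 1 depends on the methyl being there. Also open, from the compounds shown here alone, is how an amine or a carboxylic acid in place of the methoxy of compound 2 would read.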